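The source may hold more compounds than are shown below. What is called first, only, known or untested is meant among the compounds shown, and "the series" means these compounds.

Of the compounds shown here, two that share one core have been tested in an ADME assay on MT4 cells (Homo sapiens) for cytotoxicity; a lower number here means that less compound is tolerated, a higher number that more compound is tolerated. Compound 1 `COC(=O)c1ccc(NC(=O)CSc2snnc2-c2ccc(OC)cc2)c(Br)c1` carries a methoxycarbonyl group, and in this assay compound 1 gives 195000 nM. Compound 2 `COc1ccc(-c2nnsc2SCC(=O)Nc2ccccc2Br)cc1` lacks that group. For compound 2 in this assay only a limit is reported, > 286000 nM. Among the compounds with values here, the single measured step between them is an at least 1.4-fold higher number from compound 1 to compound 2 (0.16 log units; that floor lies within the scatter). Compound 2 therefore stands at the edge of what this assay can report, at the limit of > 286000 nM in this assay, at which 1 of the 2 values shown sits, so no exact number is known for it.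

The next compound, compound 3 `CCOC(=O)c1ccc(NC(=O)CSc2snnc2-c2ccc(OC)cc2)c(Br)c1`, differs from compound 2 in one place: ethoxycarbonyl in place of hydrogen on an aromatic carbon. Within the data shown here, this change is close to a reversal of the one measured step, since ethoxycarbonyl and methoxycarbonyl are closely related groups. That measured step was small, with a floor inside the scatter, so compound 3 is expected to show at most a small step, if anything downward: an at least 1.4-fold lower number from compound 2 to compound 3 (0.15 log units; that floor lies within the scatter). For compound 3 in this assay a value around 200000 nM is estimated, between 100000 nM and 400000 nM.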

Compound 3, half-maximal cytotoxic concentration: > 245000 nM
Compound 3: only a limit was reported; the forecaster's own chance of this, stated with the estimate: 40%; middle value at least 1.2-fold (0.08 log units) away from the limit.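

Compound 3 is known only as a limit of the assay, not as an exact number: the limit of > 245000 nM in this assay, at which 1 of the 3 values shown sits. Replacing methoxycarbonyl with ethoxycarbonyl on this aromatic carbon, para to a large group and meta to a bromo group, gives an at least 1.2-fold higher number from compound 1 to compound 3 (0.09 log units; that floor lies within the scatter) in this assay, so adding a methyl to the end of the ester brings no change that stands clear of the usual scatter. Compound 2 and compound 3 both carry limits, so the step between them cannot be read, but it does show that an ester at this position can still reach a limit, as the unsubstituted hydrogen compound does, with the ethoxycarbonyl group's five heavy atoms in place.

The compounds shown leave open where the true values of compound 2 and compound 3 lie, and so whether any ester at this position lowers the tolerated concentration at all. Also open, from the compounds shown here alone, is whether a carboxylic acid or an amine on this aromatic carbon, or a longer chain on the ester, would give a number in this assay that stands clearly apart from that of compound 1.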